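This account rests on a few compounds, and the source may have more. Where it says the series, first, only, none or still open, it means among the compounds named here.

Three compounds have so far been measured in a functional assay on MDA-MB-231 cells (Homo sapiens) for cytotoxicity, read by sulforhodamine B assay, with a stated time of 72 h; a higher number here means a weaker inhibitor of growth, a lower number a stronger inhibitor of growth:

Compound 1 `O=C(Nc1ccccc1C(F)(F)F)C1CCc2ccccc2N1C(=O)c1ccccc1` gives 5290 nM.
Compound 2 `O=C(Nc1ccccc1C(F)(F)F)C1CCc2ccccc2N1C(=O)c1ccccc1Cl` gives 2530 nM.
Compound 3 `O=C(Nc1ccccc1O)C1CCc2ccccc2N1C(=O)c1ccccc1` gives 4210 nM.

Compound 3 stands second highest of these three numbers; its gap to compound 1 and its gap to compound 2 are both within the scatter, so nothing firm separates it from either.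

The compound that comes next is compound 4 `O=C(Nc1ccccc1O)C1CCc2ccccc2N1C(=O)c1ccccc1Cl`. It differs from compound 3 by one change: chloro in place of hydrogen on an aromatic carbon. For the measured compounds named here, one measured step bears directly on this, because the same change was already made on the same ring: a 2.1-fold lower number from compound 1 to compound 2 (0.32 log units; beyond the scatter). The other step, a 1.3-fold lower number from compound 1 to compound 3 (0.10 log units; within the scatter), shows that swapping the group on the other ring hardly moved the number, which suggests the two ring series behave alike here. On that basis a modest lowering of the number is expected; the expected step is a 2.1-fold lower number from compound 3 to compound 4 (0.32 log units; beyond the scatter). Compound 4 is therefore estimated at 2000 nM, with a range from 1000 nM to 4500 nM.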

Compound 4, concentration for 50% growth inhibition: 47400 nM
Beside the measured number, compound 4's estimate is 24-fold (1.37 log units) below it; the whole stated range lies below it.
By their numbers in this assay, from the lowest: compounds 2, 3 and 1 (each within the scatter of the next, the first and the last beyond it); then compound 4.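

Putting chloro on this aromatic carbon, ortho to a large group, gives an 11-fold higher number from compound 3 to compound 4 (1.05 log units; beyond the scatter) in this assay, so the change that lowered the number in the trifluoromethyl pair raises it sharply in the hydroxy pair: the same change on two cores in this assay, a 2.1-fold lower number (0.32 log units; beyond the scatter) from compound 1 to compound 2 and an 11-fold higher number (1.05 log units; beyond the scatter) from compound 3 to compound 4, 24-fold (1.37 log units) apart, beyond the scatter of two such steps

Read the other way, hydroxy in place of trifluoromethyl gives a 19-fold higher number from compound 2 to compound 4 (1.27 log units; beyond the scatter), although the same swap left the number within the scatter when chloro was absent: the same change on two cores in this assay, a 1.3-fold lower number (0.10 log units; within the scatter) from compound 1 to compound 3 and a 19-fold higher number (1.27 log units; beyond the scatter) from compound 2 to compound 4, 24-fold (1.37 log units) apart, beyond the scatter of two such steps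

The two changes therefore do not simply add up, and what each one does depends on the other.

These compounds cannot tell whether this reversal belongs to chloro and hydroxy alone. Whether fluoro or methyl in place of the chloro, or methoxy in place of the hydroxy, would give the same reversal remains open, as does its cause.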